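Second chlorine on a lipoic-acid coumarin hybrid

The source may report more compounds than this note shows. Statements on the series, on what has been measured and on what is new or still open speak of the compounds shown alone.

Compound 1, `O=C(CCCCC1CCSS1)NCc1cn(CCCOc2ccc3cc(-c4ccccc4)c(=O)oc3c2)nn1`, compound 2, `O=C(CCCCC1CCSS1)NCc1cn(CCCOc2ccc3cc(-c4ccc(Cl)cc4)c(=O)oc3c2)nn1`, and compound 3, `O=C(CCCCC1CCSS1)NCc1cn(CCCCOc2ccc3cc(-c4ccc(Cl)cc4)c(=O)oc3c2)nn1`, have been measured in a functional assay on PC-12 cells (Rattus norvegicus) for cytotoxicity, read by MTT assay, with stated times of 3 h and 2 h, tested at 5 uM; on this read-out higher numbers stand for a stronger effect at the one concentration tested and lower numbers for a weaker effect. Compound 1 gives 29.8%, compound 2 gives 60.6%, and compound 3 gives 52%. The change chloro in place of hydrogen on an aromatic carbon made a step of a number 30.8 percentage points higher from compound 1 to compound 2 (beyond the scatter) in this assay. The values of compound 2 and compound 3 lie within the scatter of each other; the difference between the core of compound 3 and that of compound 1 is not broken down here.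

Compound 4, `O=C(CCCCC1CCSS1)NCc1cn(CCCCOc2ccc3cc(-c4ccc(Cl)c(Cl)c4)c(=O)oc3c2)nn1`, has not yet been measured. It differs from compound 3 by chloro in place of hydrogen on an aromatic carbon. This is the same kind of change as that from compound 1 to compound 2, though not the same: in compound 2 the chloro sits para to a large group, whereas in compound 4 it sits ortho to a chloro group and meta to a large group. Because the step of a number 30.8 percentage points higher from compound 1 to compound 2 (beyond the scatter) was large, a further rise is expected from compound 3 to compound 4, estimated at a number 10 percentage points higher from compound 3 to compound 4 (within the scatter), though a second chloro may add less than the first. In this assay compound 4 is expected to give about 62%, between 45% and 78%.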

Compound 4, a percentage reported as activity, at one concentration (the size of the read-out at that concentration, not a potency): 53.2%
Compound 4: middle estimate off by 8.8 percentage points, on the high side; measured number inside the range.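

In this assay, the second chlorine, taking 4-chlorophenyl to 3,4-dichlorophenyl, gave a number 1.2 percentage points higher from compound 3 to compound 4 (within the scatter). The size of this change therefore did not carry over from one case to the other in this series: the same change on two cores in this assay, a number 30.8 percentage points higher (beyond the scatter) from compound 1 to compound 2 and a number 1.2 percentage points higher (within the scatter) from compound 3 to compound 4, 29.6 percentage points apart, beyond the scatter of two such steps What this does not show is whether the core alone sets the size of the step, since the two steps also differ in the ring they act on: the chloro of compound 2 enters a ring that carries no chloro, whereas that of compound 4 sits ortho to a chloro group and meta to a large group, and each number comes from a single concentration, so it says nothing about potency.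

The compounds shown leave open how a 3,4-dichlorophenyl group would read on the core of compound 1, a comparison that would set the core apart from the chlorine already present. They also leave open how a methoxy group or an amine on the same ring, or a longer chain in the linker, would read in this assay.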